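Moving the nitro group on a thiourea side chain

The compounds below may be only part of what the source reports. "The series", "measured", "known", "first", "only" and "open" are said of these compounds alone.

Measured compounds:
Compound 1 `COc1cc2c(cc1OC)C(=O)C(CC1CCN(C(=S)Nc3ccccc3)CC1)C2` gives 300 mg/kg
Compound 2 `COc1cc2c(cc1OC)C(=O)C(CC1CCN(C(=S)Nc3ccc(C)cc3)CC1)C2` gives 100 mg/kg
Compound 3 `COc1cc2c(cc1OC)C(=O)C(CC1CCN(C(=S)Nc3ccccc3[N+](=O)[O-])CC1)C2` gives 300 mg/kg

These three share one core and differ only in the aryl group attached to the thiourea nitrogen. In a functional assay on the whole organism (strain Swiss albino) with Mus musculus as the target, in the maximal electroshock model, with a stated time of 4 h (a higher number here means that more compound is needed for the effect, a lower number that less compound is needed), compound 3 sits level with compound 1, and together they show the highest numbers of the three; its distance from compound 2 is a 3.0-fold higher number from compound 2 to compound 3 (0.48 log units; beyond the scatter). The step of no change at the digits printed from compound 1 to compound 3 (within the scatter) shows that adding the nitro group to the plain phenyl ring did nothing that the scatter cannot explain, whereas a 3.0-fold lower number from compound 1 to compound 2 (0.48 log units; beyond the scatter) shows that a methyl group on the ring brought a modest improvement.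

Compound 4 `COc1cc2c(cc1OC)C(=O)C(CC1CCN(C(=S)Nc3ccc([N+](=O)[O-])cc3)CC1)C2` is the next candidate, with the change (4-nitrophenyl in place of 2-nitrophenyl on an amide-type nitrogen). Among the measured compounds shown here, no measured step moves a group from one ring position to another, so the only guide is that a group placed as in compound 2 helped while the nitro group placed as in compound 3 did not. The step of a 1.5-fold lower number from compound 3 to compound 4 (0.18 log units; within the scatter) is therefore expected to be small, pointing toward a somewhat lower number. For compound 4 the estimated result in this assay is 200 mg/kg, within a range from 100 mg/kg to 300 mg/kg.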

Compound 4, minimum effective dose: 300 mg/kg
Beside the measured number, compound 4's estimate is 1.5-fold (0.18 log units) below it, and the stated range covers the measured number.
By their numbers in this assay, from the lowest: compound 2; then compounds 1, 3 and 4 (each within the scatter of the next).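

In this assay, among the compounds shown here, moving the nitro group from the 2-nitrophenyl to the 4-nitrophenyl arrangement on the amide-type nitrogen gives no change at the digits printed from compound 3 to compound 4 (within the scatter) and so shows what the earlier compounds could not: in this pair, shifting the nitro group around the ring leaves the dose needed unchanged. The 4-nitrophenyl group also matches the plain phenyl group, with no change at the digits printed from compound 1 to compound 4 (within the scatter) in the comparison, whereas nitro in place of methyl gives a 3.0-fold higher number from compound 2 to compound 4 (0.48 log units; beyond the scatter) and so shows that the modest gain of compound 2 is lost when nitro replaces its methyl group. Nothing given here bears on why these numbers fall as they do.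

Methyl is the only group in this series that lowers the number, so it remains open whether that gain is specific to methyl or extends to a longer chain such as ethyl. Going by these compounds, it is also open how the number would respond to a different kind of ring substituent, such as an amine or a carboxylic acid, in place of the nitro group.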